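This account rests on a few compounds, and the source may have more. Where it says the series, first, only, none or still open, it means among the compounds named here.

Measured so far:
compound 1, `Cc1cc(C)n(-c2nc(-c3ccccc3)c(C)c(=O)[nH]2)n1`: 65%
compound 2, `Cc1cc(C)n(-c2nc(C(F)(F)F)cc(=O)[nH]2)n1`: > 99%

Both values come from an ADME assay on microsomes from liver (Homo sapiens) for metabolic stability, with a stated time of 30 min; a higher number here means that more of the compound is left, a lower number that less of the compound is left. Compound 1 gives 65% in this assay. For compound 2 the reported value is a limit of the assay and not a number; compound 2 sits at the limit of > 99% in this assay, at which 1 of the 2 values shown sits. No step between compound 1 and compound 2 is counted here, as the two differ in more than one place; their two values simply show the two readings given above.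

Compound 3 `Cc1cc(NC2CCOCC2)n(-c2nc(C(F)(F)F)cc(=O)[nH]2)n1` is not yet measured. It differs from compound 2 by (oxan-4-yl)amino in place of methyl on an aromatic carbon. Among the measured compounds shown here, with no measured step of this kind to lean on, the expected direction is a modest loss, at or just beyond the usual scatter, starting from a compound 2 that already sits at a limit. Compound 3 is therefore estimated at 85%, with a range from 60% to 99%. The expected step is a number at least 14 percentage points lower from compound 2 to compound 3 (beyond the scatter).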

Compound 3, percent of the compound remaining: > 99%
Compound 3 ended at the assay's limit; the forecaster's own chance of this, stated with the estimate: 30%; middle value at least 14 percentage points away from the limit.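

Compound 2 and compound 3 both sit at a limit of the assay and not at a number, so no step can be read between them: the limit of > 99% in this assay, at which 2 of the 3 values shown sit.

The compounds shown leave open whether (oxan-4-yl)amino in place of methyl on an aromatic carbon shifts the reading in this assay at all, and in which direction.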